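Branched to benzylic: the N-substituent step to compound 4

This account rests on a few compounds, and the source may have more. Where it says the series, first, only, none or still open, it means among the compounds named here.

Compounds measured in an assay on Prostate gland for inhibition of steroid 5-alpha-reductase (Rattus norvegicus); on this read-out higher numbers stand for weaker inhibition and lower numbers for stronger inhibition:
compound 1, `CCCCn1ccc2cc(/C(C)=C/C(=O)Nc3ccccc3OCCCC(=O)O)ccc21`, 43 nM;
compound 2, `CCCCCCCn1ccc2cc(/C(C)=C/C(=O)Nc3ccccc3OCCCC(=O)O)ccc21`, 120 nM;
compound 3, `CCCCC(CC)n1ccc2cc(/C(C)=C/C(=O)Nc3ccccc3OCCCC(=O)O)ccc21`, 7.1 nM.

Compound 3 gives the lowest number of the three in this assay, with steps a 6.1-fold lower number from compound 1 to compound 3 (0.78 log units; beyond the scatter) and a 17-fold lower number from compound 2 to compound 3 (1.23 log units; beyond the scatter), both beyond the scatter. Compound 4, `C/C(=C\C(=O)Nc1ccccc1OCCCC(=O)O)c1ccc2c(ccn2Cc2ccc(C(F)(F)F)cc2)c1`, differs from compound 3 by 4-(trifluoromethyl)benzyl in place of 1-ethylpentyl on an aromatic nitrogen. Going by the values given here, no measured step involves an aromatic substituent on this nitrogen, so neither step bears on it directly; the two steps only show that the 1-ethylpentyl group gives lower numbers than butyl or heptyl. Replacing it with 4-(trifluoromethyl)benzyl is therefore expected to move the number upward, by about a 5.6-fold higher number from compound 3 to compound 4 (0.75 log units; beyond the scatter). Compound 4 is thus estimated at 40 nM in this assay, within a range of 8 nM to 200 nM.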

Compound 4, half-maximal inhibitory concentration: 300 nM
Compound 4: middle estimate off by 7.5-fold (0.88 log units), on the low side; measured number outside the range, above it.
By their numbers in this assay, from the lowest: compound 3; then compound 1; then compound 2; then compound 4.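

In this assay the 4-(trifluoromethyl)benzyl group on the aromatic nitrogen loses far more than any earlier change gained, with a 42-fold higher number from compound 3 to compound 4 (1.63 log units; beyond the scatter) against the branched chain. It also stands above both unbranched chains, with a 7.0-fold higher number from compound 1 to compound 4 (0.84 log units; beyond the scatter) and a 2.5-fold higher number from compound 2 to compound 4 (0.40 log units; beyond the scatter) and so gives the highest number of the four. No available evidence accounts for this rise. The compounds shown leave open whether the rise belongs to the benzyl ring or to its trifluoromethyl group. An unsubstituted benzyl or a cyclohexylmethyl group on this nitrogen would bear on that question.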